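The compounds below may be only part of what the source reports. "The series", "measured", "known", "first", "only" and "open" are said of these compounds alone.

Measured in a functional assay on U-937 cells (Homo sapiens) for inhibition, read by WST assay, with a stated time of 4 days; a higher number here means a weaker inhibitor, a lower number a stronger inhibitor:
- Compound 1 `CC(C)(C)c1ccc(CN2CCN(S(=O)(=O)Nc3ccc(SCCc4ccccc4)cc3C(=O)O)CC2)cc1`: 19900 nM
- Compound 2 `CCC(=O)N1CCN(c2c3ccc(-c4cccc(F)c4)cc3nn2Cc2ccccc2)CC1`: 9300 nM

Of these two, compound 2 has the lower number, at 9300 nM, and its gap to compound 1, at 19900 nM, lies beyond the usual scatter. Compound 3 `C=CC(=O)N1CCN(c2c3ccc(-c4cccc(F)c4)cc3nn2Cc2ccccc2)CC1` has not yet been measured. It keeps the core of compound 2 but carries vinyl in place of ethyl on a carbonyl carbon. This turns 4-propanoylpiperazin-1-yl into 4-(vinylcarbonyl)piperazin-1-yl. Among the compounds with values here, no measured pair shows this change, so the expectation is uncertain and rests on the structural change alone. In this assay, a moderate step towards a lower number, beyond the scatter, is expected. The estimated size of this move is a 2.7-fold lower number from compound 2 to compound 3 (0.42 log units; beyond the scatter). For compound 3 the estimated value is 3500 nM, with an expected range of 700 nM to 12000 nM.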

Compound 3, half-maximal inhibitory concentration: 2800 nM
Compound 3: middle estimate off by 1.3-fold (0.10 log units), on the high side; low and high end bracket the measured number.
By their numbers in this assay, from the lowest: compound 3; then compound 2; then compound 1.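

Within the data shown here, compound 2 and compound 3 form the first pair here that differs in one place, giving the first reading of this position on a carbonyl carbon whose other neighbour is an amide-type nitrogen in a ring. In this assay, vinyl in place of ethyl gives a 3.3-fold lower number from compound 2 to compound 3 (0.52 log units; beyond the scatter), so this position responds beyond the scatter to a swap that keeps the same count of heavy atoms and adds one double bond outside aromatic rings. No measurement among those shown offers an explanation for this step.

The compounds shown leave open how a methyl group, a longer chain or an ethynyl group would read on the same carbonyl carbon. They also leave open whether vinyl in place of ethyl would give a similar step on the core of compound 1.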